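The source may hold more compounds than are shown below. What is called first, only, known or untested is meant among the compounds shown, and "the series" means these compounds.

Of the compounds shown here, three sharing one core have been tested in a functional assay on ECa-109 cells for inhibition, with ECa-109 cell line (Homo sapiens) as the target, read by sulforhodamine B assay (on this read-out higher numbers stand for weaker inhibition and lower numbers for stronger inhibition), and they differ only in the group on an amine nitrogen. Compound 1 `O=C1C=C(NC2CCCC2)C(=O)c2c1nc1n2[C@H]2OC[C@@H](O)[C@H]2OC1`, which carries cyclopentyl, gives > 16000 nM, and this is a limit of the assay, not a number. Compound 2 `COc1ccccc1NC1=CC(=O)c2nc3n(c2C1=O)[C@H]1OC[C@@H](O)[C@H]1OC3`, which carries 2-methoxyphenyl, gives > 4000 nM, again a limit. Going by the values given here, compound 3 `O=C1C=C(Nc2ccc(I)cc2)C(=O)c2c1nc1n2[C@H]2OC[C@@H](O)[C@H]2OC1`, which carries 4-iodophenyl, gives 2300 nM, the only true number of the three.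

Compound 4 `O=C1C=C(N2CCCC2)C(=O)c2c1nc1n2[C@H]2OC[C@@H](O)[C@H]2OC1` has pyrrolidin-1-yl in place of (4-iodophenyl)amino on a double-bonded ring carbon. The aromatic ring is lost, and a five-membered non-aromatic ring takes its place.

The most useful guide is an at least 6.9-fold lower number from compound 1 to compound 3 (0.84 log units; beyond the scatter), since that step also links a five-membered non-aromatic ring with the 4-iodophenyl group. Read in reverse, it points to a higher number for compound 4. The other step that reaches compound 3, an at least 1.7-fold lower number from compound 2 to compound 3 (0.24 log units; that floor lies within the scatter), has a floor within the scatter and adds little. a step that the two limits leave unreadable from compound 1 to compound 2 cannot be sized.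

A modest rise is therefore expected in this assay, meaning weaker inhibition. The estimated change is a 4.3-fold higher number from compound 3 to compound 4 (0.64 log units; beyond the scatter). For compound 4 the expected value is 10000 nM, with an estimated range from 3500 nM to 30000 nM.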

Compound 4, half-maximal inhibitory concentration: > 16000 nM
Compound 4: a limit, no number; the forecaster's own chance of this, stated with the estimate: 45%; middle value at least 1.6-fold (0.20 log units) away from the limit.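

In this assay compound 4 gives > 16000 nM, which is a limit and not a number. Going by these compounds alone, replacing (4-iodophenyl)amino with pyrrolidin-1-yl on this double-bonded ring carbon produces an at least 6.9-fold higher number from compound 3 to compound 4 (0.84 log units; beyond the scatter), showing for the first time that a group joined through a ring nitrogen, with no hydrogen-bond donor, gives weaker inhibition than the one compound here with a true number. The steps linking compound 4 with compound 1 and compound 2 run between two limits and cannot be read, and compound 4 shares its limit with compound 1: the limit of > 16000 nM in this assay, at which 2 of the 4 values shown sit.

This single change removes the six-membered aromatic ring and the hydrogen-bond donor together, and the compounds shown cannot separate the two losses or say how far inhibition falls beyond the limit. Going by these compounds, a (4-iodophenyl)(methyl)amino group would keep the aromatic ring while carrying no hydrogen on the nitrogen, and it remains open how that group would read, as does whether a morpholin-4-yl group would also end at a limit.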